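Chloro to Bromo on a Shared Aryl Amide

This account rests on a few compounds, and the source may have more. Where it says the series, first, only, none or still open, it means among the compounds named here.

Measured compounds:
Compound 1, `COc1ccc(-c2cc(C(=O)Nc3ccc(Oc4ccnc5[nH]ccc45)cc3)ncn2)cc1`, gives 4410 nM in a functional assay on A549 cells (Homo sapiens) for cytotoxicity, read by MTT assay, with a stated time of 72 h; a higher number here means a weaker inhibitor, a lower number a stronger inhibitor.
Compound 2, `O=C(Nc1ccc(Oc2ccnc3[nH]ccc23)cc1)c1cc(-c2ccc(Cl)cc2)ncn1`, gives 6530 nM in this assay.

Compound 2 and compound 1 are the only two measured so far, and their numbers in this assay lie within the usual scatter of each other, so neither can be called the stronger. Compound 3, `O=C(Nc1ccc(Oc2ccnc3[nH]ccc23)cc1)c1cc(-c2ccc(Br)cc2)ncn1`, differs from compound 2 in a single place: bromo in place of chloro on an aromatic carbon. Within the data shown here, one measured step bears on this position, a 1.5-fold higher number from compound 1 to compound 2 (0.17 log units; within the scatter), which exchanged one small group for another at the same carbon and stayed within the scatter. Exchanging chloro for bromo is a change of the same kind, so no shift beyond the scatter is expected in this assay. The step expected from this exchange is a 1.1-fold lower number from compound 2 to compound 3 (0.04 log units; within the scatter). Compound 3 is therefore estimated to give about 6000 nM in this assay, with a likely range from 2500 nM to 14000 nM.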

Compound 3, half-maximal inhibitory concentration: 9870 nM
Beside the measured number, compound 3's estimate is 1.6-fold (0.22 log units) below it; the measured number falls inside the stated range.
By their numbers in this assay, from the lowest: compounds 1, 2 and 3 (each within the scatter of the next, the first and the last beyond it).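

Exchanging chloro for bromo on this aromatic carbon gives a 1.5-fold higher number from compound 2 to compound 3 (0.18 log units; within the scatter) in this assay, so this pair of halogens cannot be told apart by this measurement. Among these compounds, the comparison of methoxy with bromo at the same carbon gives a 2.2-fold higher number from compound 1 to compound 3 (0.35 log units; beyond the scatter), the first step at this position to pass beyond the scatter, though only modestly, while the chloro compound 2 stays within the scatter of both neighbours. Nothing shown here offers a reason for this small gap.

From the compounds shown here alone, all three groups at this carbon are single small substituents, so it remains open whether an amine, a carboxylic acid or a longer chain such as butoxy would move the number much further. Going by these compounds, it is also open whether a bare hydrogen at this carbon would give a number close to these three.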